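This account rests on a few compounds, and the source may have more. Where it says the series, first, only, none or still open, it means among the compounds named here.

Measured so far in a functional assay on the whole organism for antagonist activity, with Mus musculus as the target; a higher number here means that more compound is needed for the effect, a lower number that less compound is needed:
- compound 1 `CC(=O)N(C)C(C)C#CCn1ccnc1`: > 100 mg/kg
- compound 2 `COC(=O)N(C)CC#CCn1ccnc1`: > 100 mg/kg
- compound 3 `COC(=O)N(C)C(C)C#CCN1CCCC1`: > 100 mg/kg

None of these three entries is a number. Each is a limit of the assay, as the series summary shows: the limit of > 100 mg/kg in this assay, at which 3 of the 3 values shown sit.

Compound 3 gives > 100 mg/kg, and this is a limit. It therefore has no ranking against the other two compounds, and it offers only a bound as a starting point.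

The next compound is compound 4 `COC(=O)N(C)C(C)C#CCn1ccnc1`, which has 1H-imidazol-1-yl in place of pyrrolidin-1-yl on a saturated chain carbon bound to a triple-bonded carbon. Compound 1 and compound 2 also carry 1H-imidazol-1-yl.

For the measured compounds named here, no measured step exists to set a size or direction for the change. In this assay, no step beyond the scatter is expected, and no direction is favoured. This expectation rests on compound 2, whose limit of > 100 mg/kg was reached with the same entering group. The estimated change is a step that the limit leaves unreadable from compound 3 to compound 4, and a further limit is the likeliest report. For compound 4 the expected dose is 120 mg/kg, with an estimated range from 50 mg/kg to 300 mg/kg.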

Compound 4, dose for half-maximal effect: > 100 mg/kg
Compound 4: a limit, no number (the forecaster's own chance of this, stated with the estimate: 75%); the middle value is on the limit's open side.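

In this assay compound 4 gives > 100 mg/kg, again a limit of the assay and not a number. The steps to compound 4 from compound 1, compound 2 and compound 3 cannot be read, because every entry is a limit: the limit of > 100 mg/kg in this assay, at which 4 of the 4 values shown sit.

The compounds shown leave open the size and direction of each of these changes in this assay.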